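Adding a chloro group to the benzyl ring of compound 2

A few compounds are considered here, and "the series" means these few. Any claim that something is new, unique, unknown or untested is made for them only; others in the source may bear on it.

Two compounds share the bis(trifluoromethyl)phenylsulfonamide core. Compound 1 `O=S(=O)(NCCCCNCc1ccc(Br)cc1)c1cc(C(F)(F)F)cc(C(F)(F)F)c1` gives 2200 nM in a functional assay on BE(2)-C cells (Homo sapiens) for inhibition, read by MTT assay, with a stated time of 72 h (on this read-out higher numbers stand for weaker inhibition of growth and lower numbers for stronger inhibition of growth), and compound 2 `O=S(=O)(NCCCNCc1ccccc1)c1cc(C(F)(F)F)cc(C(F)(F)F)c1` gives 12000 nM in this assay, the highest of the two numbers; the step of a 5.5-fold higher number from compound 1 to compound 2 (0.74 log units; beyond the scatter) is the only one available. The next compound, compound 3 `O=S(=O)(NCCCNCc1cccc(Cl)c1)c1cc(C(F)(F)F)cc(C(F)(F)F)c1`, differs from compound 2 by chloro in place of hydrogen on an aromatic carbon. Within the data shown here, the single measured step changes both the chain and the halogen at once, so it bears only loosely on this change, but it points toward a lower number when a halogen is present on the benzyl ring. The expected step of a 2.4-fold lower number from compound 2 to compound 3 (0.38 log units; beyond the scatter) is therefore modest and downward, toward stronger inhibition of growth. Compound 3 is estimated at 5000 nM, with a range from 1800 nM to 14000 nM.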

Compound 3, concentration for 50% growth inhibition: 6900 nM
Compound 3: middle estimate off by 1.4-fold (0.14 log units), on the low side; the measured number falls inside the stated range.
By their numbers in this assay, from the lowest: compound 1; then compounds 3 and 2 (each within the scatter of the next).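

In this assay, chloro in place of hydrogen on an aromatic carbon, meta to a large group, gives a 1.7-fold lower number from compound 2 to compound 3 (0.24 log units; within the scatter), so on the chain of compound 2 this 3-chlorobenzyl group does not separate from the plain benzyl group. The step of a 3.1-fold higher number from compound 1 to compound 3 (0.50 log units; beyond the scatter) is beyond the scatter, but it changes the chain and the halogen together, so it cannot be assigned to either one alone. No outside measurement offers an explanation for these numbers.

From the compounds shown here alone, it remains open whether a 4-bromobenzyl group on the chain of compound 2, or a plain benzyl group on the chain of compound 1, would show which change carries the gap. Going by these compounds, how a methoxy group or a nitrile would read on this ring also remains open.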